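The source may hold more compounds than are shown below. What is called first, only, known or untested is meant among the compounds shown, and "the series" means these compounds.

Measured compounds:
- compound 1 `COc1cc(-c2nn(-c3cccc(NC(=O)Nc4cc(C(F)(F)F)cc(C(F)(F)F)c4)c3)cc2-c2ccncc2)ccc1Cl`: 3000 nM
- compound 2 `O=C(Nc1cccc(-n2cc(-c3ccncc3)c(-c3ccc(Cl)c(O)c3)n2)c1)Nc1ccc(Cl)c(Cl)c1`: a limit, > 32500 nM

Among the measured compounds shown here, in a functional assay on MDA-MB-231 cells (Homo sapiens) for inhibition, read by sulforhodamine B assay, with a stated time of 48 h (on this read-out higher numbers stand for lower toxicity in this test and lower numbers for higher toxicity in this test), compound 1 gives 3000 nM, the only plain number among the values shown. Compound 2, for its part, gives no number in this assay but only a limit, > 32500 nM. So compound 1 stands as the single fixed point, with the other value being (the limit of > 32500 nM in this assay, at which 1 of the 2 values shown sits), and no step between two measured compounds can be drawn from this pair; their two values show only that compound 1 has a number where compound 2 has none.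

Compound 3 `COc1cc(-c2nn(-c3cccc(NC(=O)Nc4cccc(C(F)(F)F)c4)c3)cc2-c2ccncc2)ccc1Cl` differs from compound 1 in one place: hydrogen in place of trifluoromethyl on an aromatic carbon, leaving the second trifluoromethyl group in place. For the measured compounds named here, with no measured step of this kind to lean on, the change is expected to cost some toxicity in this assay, a step of moderate size toward higher numbers, and it could still fall within the scatter. Compound 3 is therefore expected to give about 6000 nM, between 1500 nM and 25000 nM, which is expected to mean a step of a 2.0-fold higher number from compound 1 to compound 3 (0.30 log units; within the scatter).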

Compound 3, concentration lethal to 50% of the cells: 25500 nM
Compound 3: middle estimate off by 4.3-fold (0.63 log units), on the low side; the whole stated range lies below it.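

In this assay, among the compounds shown here, hydrogen in place of trifluoromethyl on an aromatic carbon gives an 8.5-fold higher number from compound 1 to compound 3 (0.93 log units; beyond the scatter), the first step that can be read, and it lies beyond the scatter. This place on the six-membered aromatic ring of carbon only, meta to a trifluoromethyl group, therefore matters in this test: with the second trifluoromethyl group left in place, the change moves the read-out toward lower toxicity, and compound 1, with both groups, is the more toxic of the pair. Nothing shown bears on why the step has this size, and the finding rests on this single pair.

On these data alone, it remains open whether a chlorine atom, a methoxy group or an amine at this place would behave like hydrogen or like trifluoromethyl, and what happens if the second trifluoromethyl group also gives way. Compound 2 remains a limit, > 32500 nM, and the steps to it cannot be read.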